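Amide chain extension in a trimethoxyphenyl benzylamide series

The source may hold more compounds than are shown below. What is called first, only, known or untested is meant among the compounds shown, and "the series" means these compounds.

Compound 1 `CCC(=O)N(Cc1ccc(OC)c(O)c1)c1cc(OC)c(OC)c(OC)c1` is the lower of the two numbers measured in a functional assay on KYSE-450 cells (Homo sapiens) for inhibition, read by MTT assay, with a stated time of 48 h; on this read-out higher numbers stand for weaker inhibition and lower numbers for stronger inhibition; in this assay compound 1 gives 98 nM. For the measured compounds named here, compound 2 `C/C=C/C(=O)N(Cc1ccc(OC)c(OC)c1)c1cc(OC)c(OC)c(OC)c1` gives 39100 nM in this assay, a gap from compound 1 that lies well beyond the scatter; no single-site step connects the two, so only the two values themselves are known.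

Compound 3 `CC/C=C/C(=O)N(Cc1ccc(OC)c(O)c1)c1cc(OC)c(OC)c(OC)c1` has not been measured. It differs from compound 1 by but-1-en-1-yl in place of ethyl on a carbonyl carbon. Going by the values given here, no step between measured compounds covers this change, so its size must be judged from the series as it stands. Among the compounds with values here, the expectation is a weakening step in this assay of a 3.6-fold higher number from compound 1 to compound 3 (0.55 log units; beyond the scatter), moderate rather than large, since the only weaker compound, compound 2, differs at more than one place and cannot be read as a guide to this change alone. Compound 3 is estimated to give 350 nM in this assay, within a range from 70 nM to 2500 nM.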

Compound 3, half-maximal inhibitory concentration: 72 nM
The estimate for compound 3 lay 4.9-fold (0.69 log units) above the measured number, and the stated range covers the measured number.
By their numbers in this assay, from the lowest: compounds 3 and 1 (each within the scatter of the next); then compound 2.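

In this assay, but-1-en-1-yl in place of ethyl on a carbonyl carbon gives a 1.4-fold lower number from compound 1 to compound 3 (0.13 log units; within the scatter) and so stays within the scatter. This position therefore accepts the but-1-en-1-yl chain with its double bond without any readable change in the number, which compound 1 alone could not show. Compound 1 and compound 3 each differ from compound 2 at more than one place, so this step does not account for the value of compound 2, 39100 nM. Nothing on hand bears on why the two chains read alike.

Open at this carbonyl carbon is how a saturated butyl chain, a longer hexenyl chain or a chain ending in an amine would read. Also open, going by these compounds, is what a methoxy group in place of the hydroxy group does on its own.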